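This account rests on a few compounds, and the source may have more. Where it says the series, first, only, none or still open, it means among the compounds named here.

In a functional assay on MCF7 cells (Homo sapiens) for cytotoxicity, read by MTT assay (a lower number here means a stronger inhibitor, a higher number a weaker inhibitor), compound 1 `COC(=O)C[C@@H]1C[C@@H](O)[C@H](C)[C@H](c2ccccc2)N1` gives 5400 nM and compound 3 `COC(=O)C[C@H]1C[C@H](O)[C@@H](C)[C@@H](c2ccc(C(C)C)cc2)N1` gives 17100 nM. Compound 2 `COC(=O)C[C@H]1C[C@@H](O)[C@@H](C)[C@@H](c2ccc(C(C)C)cc2)N1` has no single number, since its result is "not active" (no number reported), which places it at the weak end of this small set. What separates it from compound 3 is the fact that compounds 2 and 3 differ only in the configuration as drawn. Compound 4 `COC(=O)C[C@H]1C[C@@H](O)[C@@H](C)[C@@H](c2ccc(F)cc2)N1` has not yet been measured and shares the drawn configuration of compound 2. The change fluoro in place of isopropyl on an aromatic carbon puts fluoro in place of isopropyl on an aromatic carbon, para to a large group. For the measured compounds named here, no measured step shows what this swap does, so with compound 2 at "not active" (no number reported), a small gain in this assay is expected, and possibly no number at all. For compound 4 the estimated value is 30000 nM, with an expected range of 9000 nM to 100000 nM.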

Compound 4, half-maximal inhibitory concentration: 15600 nM
The estimate for compound 4 lay 1.9-fold (0.28 log units) above the measured number; the range from low to high includes it.
By their numbers in this assay, from the lowest: compound 1; then compounds 4 and 3 (each within the scatter of the next).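

No step can be read from compound 2 to compound 4: compound 2 has no number to compare with. The compounds shown leave open how far fluoro in place of isopropyl changes cytotoxicity on its own.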